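The source may report more compounds than this note shows. Statements on the series, on what has been measured and on what is new or still open speak of the compounds shown alone.

Going by the values given here, compound 2, `CCCC(Oc1ccc(-n2cc3c(n2)CCCC3)cc1)c1ccc(C(=O)NCCC(=O)O)cc1`, is the faster-cleared of the two compounds measured so far in an ADME assay on microsomes from liver (Homo sapiens) for metabolic stability; a higher number here means faster removal of the compound, a lower number slower removal: compound 2 gives 48 mL/min/kg, whereas compound 1, `CCCC(Oc1ccc(-n2cc(C)cn2)cc1)c1ccc(C(=O)NCCC(=O)O)cc1`, gives 16 mL/min/kg. Among the compounds with values here, the one comparison available, a 3.0-fold higher number from compound 1 to compound 2 (0.48 log units; beyond the scatter), shows that enlarging the ring substituent on the shared core goes with a faster clearance.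

Compound 3, `CCCC(Oc1ccc(-n2cc(OC)cn2)cc1)c1ccc(C(=O)NCCC(=O)O)cc1`, has not yet been measured. It differs from compound 2 in one place, (a group of 7 heavy atoms (4 carbon, 2 nitrogen, 1 oxygen; one five-membered aromatic ring with 2 hetero atoms) in place of a group of 9 heavy atoms (7 carbon, 2 nitrogen; one five-membered aromatic ring with 2 hetero atoms, one six-membered non-aromatic ring of carbon only), on an aromatic carbon). This change runs the same comparison in reverse: the larger bicyclic group is replaced by a small single ring, much as compound 1 carries a small single ring. Within the data shown here, only the step from compound 1 to compound 2 bears on it, and that step was modest but beyond the scatter. A drop of roughly that size, a 2.7-fold lower number from compound 2 to compound 3 (0.43 log units; beyond the scatter), is therefore expected, bringing compound 3 back near the level of compound 1, with a wide margin since the entering group is not identical to that of compound 1. For compound 3 the estimated clearance is 18 mL/min/kg, within a range from 9 mL/min/kg to 36 mL/min/kg.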

Compound 3, clearance in the Homo sapiens assay: < 8 mL/min/kg
Compound 3: no number, only a limit (the forecaster's own chance of this, stated with the estimate: 5%); middle value at least 2.2-fold (0.35 log units) away from the limit.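

In the Homo sapiens assay compound 3 gives < 8 mL/min/kg, a limit of the assay and not a number. At this place, on an aromatic carbon para to a large group, the Homo sapiens assay shows that putting 4-methoxy-1H-pyrazol-1-yl in place of the larger two-ring group gives an at least 6.0-fold lower number from compound 2 to compound 3 (0.77 log units; beyond the scatter), while methoxy in place of methyl gives an at least 2.0-fold lower number from compound 1 to compound 3 (0.30 log units; that floor lies within the scatter), so the two small groups cannot be put in order. A second read-out now accompanies the clearance change: in a physicochemical assay for lipophilicity, using the shake flask method, at pH 7.4 (on this read-out higher numbers stand for higher lipophilicity and lower numbers for lower lipophilicity), compound 2 gives 2.7 and compound 3 gives 1.4, which is a number 1.30 log units lower from compound 2 to compound 3 (beyond the scatter), so clearance and distribution coefficient fall together in this one pair.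

One pair cannot separate a link between those two read-outs from the loss of the six-membered ring, and the limit leaves open how far the clearance of compound 3 actually lies beneath that of compound 2. From the compounds shown here alone, how an ethoxy group, a nitrile or an amine in place of the methoxy group would behave also remains open.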